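A few compounds are considered here, and "the series" means these few. Any claim that something is new, unique, unknown or untested is made for them only; others in the source may bear on it.

In an assay on HEK293 cells for positive allosteric modulation of metabotropic glutamate receptor 3 (Rattus norvegicus), read by thallium flux, with a stated time of 2.5 min (on this read-out lower numbers stand for an effect already at smaller amounts and higher numbers for an effect only at larger amounts of compound), compound 1 `Cc1cc(C(=O)O)ccc1OCCCCOc1ccc(C(=O)CC(C)C)c(O)c1C` gives 1850 nM. Compound 2 `Cc1cc(C(=O)O)ccc1OCCCCOc1ccc(C(=O)C(C)C)c(O)c1C` returns "not determined" (no result reported) in this assay, so no number places it on this scale. Compound 3 `Cc1cc(C(=O)O)ccc1OCCCCOc1ccc(C(=O)CC2CCCC2)c(O)c1C` differs from compound 2 by cyclopentylmethyl in place of isopropyl on a carbonyl carbon. Since compound 2 has no value, nothing measured anchors the size of this step; the larger group is expected to move the value of this assay at most modestly toward lower numbers, hardly beyond the scatter. Compound 3 is therefore estimated to give 1500 nM, within a range from 400 nM to 6000 nM.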

Compound 3, half-maximal effective concentration: > 10000 nM
Compound 3 gave a limit, no number (the forecaster's own chance of this, stated with the estimate: 20%); at least 6.6-fold (0.82 log units) between middle value and limit.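

Compound 3 reaches only a limit, not a number, in this assay: > 10000 nM. Cyclopentyl in place of isopropyl on the saturated chain carbon bound to the carbonyl carbon gives an at least 5.4-fold higher number from compound 1 to compound 3 (0.73 log units; beyond the scatter), so at this place the ring costs effect rather than adding to it. The true size of this step stays unknown, since it rests on a limit: the limit of > 10000 nM in this assay, at which 1 of the 3 values shown sits.

The step from compound 2 to compound 3 cannot be read, as compound 2 has no value. Going by these compounds, whether a cyclopropyl ring or a chain ending in an amine at this place would keep the effect stays open.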